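The source may hold more compounds than are shown below. What is called first, only, known or untested is meant among the compounds shown, and "the series" means these compounds.

In a functional assay on MCF7 cells (Homo sapiens) for cytotoxicity, read by MTT assay, with a stated time of 72 h (a lower number here means a stronger inhibitor, a higher number a weaker inhibitor), compound 1 `CNC(=O)c1cc(Oc2ccc(NC(=O)c3nccc(-c4ccc([N+](=O)[O-])cc4)n3)cc2)ccn1` gives > 100000 nM. That result is a limit of the assay and not a number. Compound 2 `CNC(=O)c1cc(Oc2ccc(NC(=O)c3nccc(-c4ccc(OC)cc4)n3)cc2F)ccn1` gives > 100000 nM, which is also a limit. Compound 3 `CNC(=O)c1cc(Oc2ccc(NC(=O)c3cc(-c4ccc(Br)cc4)ncn3)cc2F)ccn1` gives > 100000 nM, again a limit. Compound 1 therefore has no exact place on the scale, and the only summary available is the limit of > 100000 nM in this assay, at which 3 of the 3 values shown sit.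

The next compound to be tested is compound 4 `CNC(=O)c1cc(Oc2ccc(NC(=O)c3nccc(-c4ccc(C)cc4)n3)cc2)ccn1`, which keeps the core of compound 1 and changes a single group. The swap sits para to a large group and turns 4-nitrophenyl into 4-methylphenyl (methyl in place of nitro on an aromatic carbon). Among the compounds with values here, no pair of tested compounds differs in only one place, so the data show no measured step for this swap or any other.

With compound 1 resting on (the limit of > 100000 nM in this assay, at which 3 of the 3 values shown sit), no step beyond the usual scatter is expected in this assay, and neither direction is favoured. In numbers, the expected step is an at least 1.4-fold lower number from compound 1 to compound 4 (0.15 log units; that floor lies within the scatter). For compound 4 the estimate is 70000 nM, with an expected range of 20000 nM to 200000 nM.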

Compound 4, half-maximal inhibitory concentration: 44300 nM
Compound 4: middle estimate off by 1.6-fold (0.20 log units), on the high side; measured number inside the range.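

Putting methyl in place of nitro gives an at least 2.2-fold lower number from compound 1 to compound 4 (0.35 log units; beyond the scatter), which shows that the group on this aromatic carbon can shift the result in this assay. Going by these compounds, compound 1 gives > 100000 nM, which is a limit and not a number, so this step has a floor and its full size remains unknown. Compound 4 is the first compound here to give a number rather than a limit, while the other values still stand at that limit: the limit of > 100000 nM in this assay, at which 3 of the 4 values shown sit.

This single pair cannot separate the loss of the nitro group from the arrival of the methyl group, and it gives no cause for the step. An amine, a carboxylic acid or a longer chain such as propyl on the same aromatic carbon, with the rest of compound 4 kept unchanged, would show whether the number can fall further or whether methyl is a special case.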